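The source may hold more compounds than are shown below. What is called first, only, known or untested is meant among the compounds shown, and "the series" means these compounds.

Measured compounds:

Compound 1, `COc1cc(C(=O)/C=C\Nc2ccc(-c3nc4cc(OC)c(OC)c(OC)c4s3)cc2C)cc(OC)c1OC`, gives 22800 nM in a functional assay on MIA PaCa-2 cells (Homo sapiens) for antiproliferative activity, read by sulforhodamine B assay, with a stated time of 48 h; a lower number here means a stronger inhibitor, a higher number a weaker inhibitor.
Compound 2, `COc1ccc(C(=O)/C=C\Nc2ccc(-c3nc4cc(OC)c(OC)c(OC)c4s3)cc2)cc1F`, gives 19400 nM in this assay.
Compound 3, `COc1ccc(C(=O)/C=C\Nc2ccc(-c3nc4cc(OC)c(OC)c(OC)c4s3)cc2)cc1O`, gives 32800 nM in this assay.

Compound 3 has the highest of the three numbers, but its nearest neighbour is compound 1 and its furthest is compound 2, and both gaps are within the scatter, so no order among the three can be read from them. Among the measured compounds shown here, the only single-change step among them, a 1.7-fold higher number from compound 2 to compound 3 (0.23 log units; within the scatter), is also within the scatter.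

Compound 4, `COc1cc(C(=O)/C=C\Nc2ccc(-c3nc4cc(OC)c(OC)c(OC)c4s3)cc2)cc(OC)c1OC`, differs from compound 3 in one place: 3,4,5-trimethoxyphenyl in place of 3-hydroxy-4-methoxyphenyl on a carbonyl carbon. For the measured compounds named here, no measured step bears directly on this exchange of the aryl group on the carbonyl carbon. What does bear on it is compound 1, which carries the same 3,4,5-trimethoxyphenyl on the carbonyl carbon and a methyl on the aniline ring in addition, and gives 22800 nM; this sits within the scatter of compound 3. All three measured compounds fall within the scatter of one another, so the aryl group on the carbonyl has so far produced no step beyond the scatter.

The step from compound 3 to compound 4 is therefore expected to be small, a 1.4-fold lower number from compound 3 to compound 4 (0.15 log units; within the scatter), in no particular direction. Compound 4 is estimated at 23000 nM, with a range from 10000 nM to 50000 nM.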

Compound 4, half-maximal inhibitory concentration: 29100 nM
Beside the measured number, compound 4's estimate is 1.3-fold (0.10 log units) below it; low and high end bracket the measured number.
By their numbers in this assay, from the lowest: compounds 2, 1, 4 and 3 (each within the scatter of the next).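

In this assay, the exchange on the carbonyl carbon now has a direct reading: 3,4,5-trimethoxyphenyl in place of 3-hydroxy-4-methoxyphenyl gives a 1.1-fold lower number from compound 3 to compound 4 (0.05 log units; within the scatter), so a larger group with no hydrogen-bond donor leaves the number within the scatter. Among the compounds shown here, the same holds for the exchange of the 3-fluoro-4-methoxyphenyl group, with a 1.5-fold higher number from compound 2 to compound 4 (0.18 log units; within the scatter), and the first reading on the methyl, hydrogen in its place on an aromatic carbon, gives a 1.3-fold higher number from compound 1 to compound 4 (0.11 log units; within the scatter), again within the scatter. Nothing measured here accounts for how little these exchanges move the number.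

On these data alone, whether a group of another kind on the carbonyl carbon, such as an amine or a carboxylic acid, would give a step beyond the scatter stays open. As far as these compounds go, it also remains open whether a longer chain such as ethyl or propyl in place of the methyl on the aromatic carbon, or a change to the shared core itself, would move the number any further than the exchanges seen so far.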